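A few compounds are considered here, and "the series" means these few. Any claim that something is new, unique, unknown or untested is made for them only; others in the source may bear on it.

Compound 1 `COC(=O)CC1CCN(C[C@H]2CN(c3ccc(-n4cc(-c5ccccn5)cn4)c(F)c3)C(=O)O2)CC1`, compound 2 `O=C1CNC(=O)N1C[C@H]1CN(c2ccc(-n3cc(-c4ccccn4)cn3)c(F)c2)C(=O)O1` and compound 3 `CS(=O)(=O)NC[C@H]1CN(c2ccc(-n3cc(-c4ccccn4)cn3)c(F)c2)C(=O)O1` share one core and differ only in the group carried on a saturated chain carbon bound to a saturated ring carbon. In a physicochemical assay for lipophilicity, read by HPLC, measured as octanol-water partition (a higher number here means a more lipophilic compound, a lower number a more polar compound), compound 1 gives 1.78, compound 2 gives 1.25 and compound 3 gives 1.38. Compound 2 thus stands lowest of the three, with compound 3 nearest and compound 1 furthest, the step of a number 0.13 log units higher from compound 2 to compound 3 (within the scatter) lying within the scatter while a number 0.53 log units lower from compound 1 to compound 2 (beyond the scatter) and a number 0.40 log units lower from compound 1 to compound 3 (beyond the scatter) lie beyond it.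

Compound 4 `CONC(=O)[C@H]1CN(c2ccc(-n3cc(-c4ccccn4)cn3)c(F)c2)C(=O)O1` is not yet measured in this assay. It differs from compound 2 by methoxycarbamoyl in place of (2,5-dioxoimidazolidin-1-yl)methyl on a saturated ring carbon. Among the measured compounds shown here, no measured step exchanges a group in this way on a ring carbon; the closest guide is the step from compound 2 to compound 3, in which one small polar group replaced another and the partition coefficient barely moved. A similar outcome is expected here, with at most a small change: the step of a number 0.10 log units lower from compound 2 to compound 4 (within the scatter) is estimated to stay within the scatter. Compound 4 is therefore expected to give about 1.15, between 0.75 and 1.55.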

Compound 4, partition coefficient: >= 1.58
Compound 4: only a limit was reported; the forecaster's own chance of this, stated with the estimate: 2%; middle value at least 0.43 log units away from the limit.
By their numbers in this assay, from the lowest: compounds 2 and 3 (each within the scatter of the next); then compound 1.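

In this assay, compound 4 has a limit and not a number: the limit of >= 1.58 in this assay, at which 1 of the 4 values shown sits.

Even so, the exchange of (2,5-dioxoimidazolidin-1-yl)methyl for methoxycarbamoyl on the saturated ring carbon gives a number at least 0.33 log units higher from compound 2 to compound 4 (beyond the scatter), so a change at this position moved the partition coefficient beyond the scatter, although the two groups have equal counts of hydrogen-bond donors and acceptors. Against the methanesulfonamido compound the reading is weaker, with a number at least 0.20 log units higher from compound 3 to compound 4 (that floor lies within the scatter), and the step that starts from compound 1 cannot be read.

The compounds shown leave open how high the true value of compound 4 lies, and whether the step goes with the lost ring or with the direct attachment of the group to the ring carbon. A methylene-linked methoxycarbamoyl, a simple amide or a carboxylic acid on that carbon would bear on this.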